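The source may report more compounds than this note shows. Statements on the series, on what has been measured and on what is new or still open speak of the compounds shown alone.

Measured so far:
compound 1 `CN(C(=O)c1ccc(Br)cc1)c1ccc2[nH]c(-c3n[nH]c4ccccc34)cc2n1` — 3460 nM
compound 2 `COc1cccc(C(=O)N(C)c2ccc3[nH]c(-c4n[nH]c5ccccc45)cc3n2)c1` — 22000 nM

Compound 2 stands at the higher of the two numbers in a functional assay on SMMC-7721 cells (Homo sapiens) for antiproliferative activity, read by MTT assay, with a stated time of 72 h (a lower number here means a stronger inhibitor, a higher number a weaker inhibitor), and the gap from compound 1 is a 6.4-fold higher number from compound 1 to compound 2 (0.80 log units; beyond the scatter). Compound 3 `CN(c1ccc2[nH]c(-c3n[nH]c4ccccc34)cc2n1)S(=O)(=O)c1ccccc1` differs from compound 2 by phenylsulfonyl in place of (3-methoxyphenyl)carbonyl on a nitrogen on an aromatic ring. Among the measured compounds shown here, only that one step bears on it, and it only shows that the group on this nitrogen matters. For the measured compounds named here, no measured step shows a sulfonyl here, so the direction is uncertain; a modest step back toward the number of compound 1 is expected, a 2.4-fold lower number from compound 2 to compound 3 (0.39 log units; beyond the scatter). Compound 3 is estimated at 9000 nM, between 2000 nM and 40000 nM.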

Compound 3, half-maximal inhibitory concentration: 12000 nM
Estimate against measurement, compound 3: 1.3-fold (0.12 log units) below, within the range that was stated.
By their numbers in this assay, from the lowest: compound 1; then compounds 3 and 2 (each within the scatter of the next).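

In this assay, phenylsulfonyl on this nitrogen gives a 1.8-fold lower number from compound 2 to compound 3 (0.26 log units; within the scatter) and so is not told apart from (3-methoxyphenyl)carbonyl. Set against (4-bromophenyl)carbonyl, the same group gives a 3.5-fold higher number from compound 1 to compound 3 (0.54 log units; beyond the scatter) and thus leaves compound 1 as the only one of the three clearly separated from both others. No evidence at hand bears on this result.

The compounds shown leave open whether a (4-bromophenyl)sulfonyl group would match compound 1 or stay with compound 3. They also leave open what a methylsulfonyl group or a simple acetyl on this nitrogen would give.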